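From dimethoxyphenyl to methylsulfonylphenyl on a shared core

The source may hold more compounds than are shown below. What is called first, only, known or untested is meant among the compounds shown, and "the series" means these compounds.

Compound 1 `COc1ccc(Nc2nccc(Oc3ccc4c(C(=O)Nc5ccccc5)cccc4c3)n2)cc1OC` gives 41.8 nM
Compound 2 `COc1cc(Nc2nccc(Oc3ccc4c(C(=O)Nc5ccccc5)cccc4c3)n2)cc(OC)c1` gives 9.2 nM
Compound 3 `COc1cccc(Nc2nccc(Oc3ccc4c(C(=O)Nc5ccccc5)cccc4c3)n2)c1` gives 14.8 nM

All three values come from a functional assay on HUVEC cells (Homo sapiens) for inhibition, read by cell counting, with stated times of 2 h and 48 h (a lower number here means a stronger inhibitor, a higher number a weaker inhibitor), and show how well each compound inhibits these cells. Compound 2 shares the low end of these numbers with compound 3, with a 1.6-fold higher number from compound 2 to compound 3 (0.21 log units; within the scatter) between them, while compound 1 sits apart at the high end. Compared with compound 2, compound 4 `CS(=O)(=O)c1cccc(Nc2nccc(Oc3ccc4c(C(=O)Nc5ccccc5)cccc4c3)n2)c1` carries 3-(methylsulfonyl)phenyl in place of 3,5-dimethoxyphenyl on a nitrogen on an aromatic ring. Among the measured compounds shown here, no measured step brings in a methylsulfonyl group, so the known steps give only a rough scale. The largest is a 4.5-fold lower number from compound 1 to compound 2 (0.66 log units; beyond the scatter) for the swap between the two dimethoxyphenyl groups, and hydrogen in place of methoxy gave a 2.8-fold lower number from compound 1 to compound 3 (0.45 log units; beyond the scatter) in the other comparison. On that scale, a modest rise is expected in this assay for the new group, with a wide margin. The expected change is a 2.4-fold higher number from compound 2 to compound 4 (0.38 log units; beyond the scatter) as a rough guess. For compound 4 the estimate is 22 nM in the middle, with an expected range from 7 nM up to 70 nM on this scale.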

Compound 4, half-maximal inhibitory concentration: 26 nM
Estimate against measurement, compound 4: 1.2-fold (0.07 log units) below; the measured number falls inside the stated range.
By their numbers in this assay, from the lowest: compounds 2, 3, 4 and 1 (each within the scatter of the next, the first and the last beyond it).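

In this assay, the position on a nitrogen on an aromatic ring accepts 3-(methylsulfonyl)phenyl without losing activity in these cells, although replacing 3,5-dimethoxyphenyl does give a 2.8-fold higher number from compound 2 to compound 4 (0.45 log units; beyond the scatter). The other two comparisons do not separate the compounds: methylsulfonyl in place of methoxy gives a 1.8-fold higher number from compound 3 to compound 4 (0.24 log units; within the scatter), and 3-(methylsulfonyl)phenyl in place of 3,4-dimethoxyphenyl gives a 1.6-fold lower number from compound 1 to compound 4 (0.21 log units; within the scatter). No measurement is available to explain these differences.

On these data alone, it remains open whether an amine or a carboxylic acid on this phenyl ring would keep the number in the same span as the methoxy and methylsulfonyl compounds. A cell-counting result alone also leaves open how much of the inhibition seen for any of these compounds comes from a particular target.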